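Aryl sulfone exchange in a metabotropic glutamate receptor 5 series

This account rests on a few compounds, and the source may have more. Where it says the series, first, only, none or still open, it means among the compounds named here.

Measured in an assay on isolated protein for displacement of a labelled ligand from metabotropic glutamate receptor 5 (Homo sapiens), with a stated time of 60 min, tested at 1 uM; a higher number here means more inhibition at the concentration tested (going by the name of the read-out), a lower number less inhibition:
compound 1 `CC1CCN(c2c(S(=O)(=O)c3ccc(F)c(F)c3)cnc3cc(Cl)ccc23)CC1`: 90%
compound 2 `Cc1ccc(S(=O)(=O)c2cnc3cc(Cl)ccc3c2N2CCC(C)CC2)cc1`: 94%
compound 3 `Cc1ccc(S(=O)(=O)c2cnc3ccc(Cl)cc3c2N2CCC(C)CC2)cc1`: 95%

Compound 2 and compound 3 are built from the same atoms joined differently; the difference between the two cores is not broken down here, and their read-outs in this assay sit close together. On the core of compound 2, the change 3,4-difluorophenyl in place of 4-methylphenyl on a sulfonyl sulfur gives a number 4 percentage points lower from compound 2 to compound 1 (within the scatter), so the exchange of the aryl group on the sulfonyl sulfur left the read-out essentially unchanged in this one measured instance.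

Compound 4 `CC1CCN(c2c(S(=O)(=O)c3ccc(F)c(F)c3)cnc3ccc(Cl)cc23)CC1` is the not yet measured partner of compound 3, carrying the same change, (3,4-difluorophenyl in place of 4-methylphenyl on a sulfonyl sulfur), at a place described in the same words as for compound 2 and compound 1. Among the compounds with values here, with only one prior example of this change, the expectation for compound 4 rests on the step from compound 2 to compound 1, a number 4 percentage points lower from compound 2 to compound 1 (within the scatter), and an estimated step of a number 4 percentage points lower from compound 3 to compound 4 (within the scatter) is therefore expected for compound 4. Compound 4 is estimated at 91% in this assay, with an expected range from 83% to 98%.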

Compound 4, a percentage reported as inhibition, at one concentration (the size of the read-out at that concentration, not a potency): 72%
Estimate against measurement, compound 4: 19 percentage points above, outside the stated range (below it).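

On the core of compound 3, 3,4-difluorophenyl in place of 4-methylphenyl on a sulfonyl sulfur gives a number 23 percentage points lower from compound 3 to compound 4 (beyond the scatter) in this assay. The size of this change therefore does not carry over intact between the two cores, and the two steps differ: the same change on two cores in this assay, a number 4 percentage points lower (within the scatter) from compound 2 to compound 1 and a number 23 percentage points lower (beyond the scatter) from compound 3 to compound 4, 19 percentage points apart, beyond the scatter of two such steps

What holds on one core is thus no safe guide to the other in this series, although both steps point the same way and the earlier one lies within the scatter. Two cores and a single exchange do not show how the change would behave on any further core, nor why the two steps differ, and a read-out at one concentration is not a potency.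

The compounds shown leave open whether 4-fluorophenyl, unsubstituted phenyl or 4-methoxyphenyl on the sulfonyl sulfur would separate the two cores in the same way. Also open, on these data alone, is whether the gap persists with another amine, such as morpholine, in place of the one shared by all four compounds.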